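From acetamido to amino: what one step can say

The source may report more compounds than this note shows. Statements on the series, on what has been measured and on what is new or still open speak of the compounds shown alone.

Measured so far in a functional assay on the whole organism (Tail) for activation, with Mus musculus as the target, with a stated time of 1 min; a higher number here means that more compound is needed for the effect, a lower number that less compound is needed
- Compound 1 (`N#Cc1ccc(-c2ccc(/C=N/N3C(=O)NC(=O)C3O)o2)cc1`) gives 743 mg/kg
- Compound 2 (`CC(=O)Nc1ccc(-c2ccc(/C=N/N3C(=O)NC(=O)C3O)o2)cc1`) gives > 1000 mg/kg

The value of compound 2 in this assay is > 1000 mg/kg and is a limit of the assay, not a number. The next molecule, compound 3 (`Nc1ccc(-c2ccc(/C=N/N3C(=O)NC(=O)C3O)o2)cc1`), carries hydrogen in place of acetyl on a nitrogen on an aromatic ring, which turns acetamido to amino.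

Going by the values given here, only one measured step bears on this change, the swap of cyano for acetamido on an aromatic carbon. On these data alone, that step is an at least 1.3-fold higher number from compound 1 to compound 2 (0.12 log units; that floor lies within the scatter) and its floor lies within the scatter, so its true size stays open. Among the compounds with values here, no compound with an amino group has been measured yet, which makes this a loose guide. Within the data shown here, with an at least 1.3-fold higher number from compound 1 to compound 2 (0.12 log units; that floor lies within the scatter) as the only evidence, no step beyond the scatter is expected in this assay for the new change, though a slight shift toward a lower number is possible. The expected step, an at least 1.2-fold lower number from compound 2 to compound 3 (0.09 log units; that floor lies within the scatter) as estimated here, is therefore small. For compound 3 the estimate is 800 mg/kg with an expected range from 350 mg/kg to 1500 mg/kg in this measurement.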

Compound 3, dose for half-maximal effect: > 1000 mg/kg
Compound 3 gave a limit, no number; the forecaster's own chance of this, stated with the estimate: 35%; middle value at least 1.2-fold (0.09 log units) away from the limit.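

In this assay compound 3 gives > 1000 mg/kg, which is a limit of the assay and not a number. Compound 2 also stands at a limit, so the change from acetamido to amino cannot be read, neither in size nor in direction, and removing the acetyl from this nitrogen has no measured effect that can be stated. Compared with the nitrile, the amino group gives an at least 1.3-fold higher number from compound 1 to compound 3 (0.12 log units; that floor lies within the scatter), so its true size stays open, just as it did for acetamido, and the same limit now appears for a second compound: the limit of > 1000 mg/kg in this assay, at which 2 of the 3 values shown sit.

The compounds shown leave open how the true values of compound 2 and compound 3 relate to each other and to compound 1, and whether the group on this aromatic carbon matters at all in this assay. A methoxy group, a carboxylic acid or a dimethylamino group in the same place could help to settle this only if it gave a real number rather than another limit.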